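Swapping a benzyl-type arm for a short chain

The source may hold more compounds than are shown below. What is called first, only, known or untested is meant among the compounds shown, and "the series" means these compounds.

Compound 1 `COc1ccc(Cn2c(=O)n(C3OC(CO)[C@@H](O)[C@H]3O)c3nc(N)nc(O)c32)cc1` carries a 4-methoxybenzyl arm on the shared core, joined to a sugar-like ring. In a functional assay with Mus musculus as the target (on this read-out lower numbers stand for an effect already at smaller amounts and higher numbers for an effect only at larger amounts of compound), compound 1 gives 2 uM, the lowest of the two numbers recorded so far. Compound 2 `C=CCn1c(=O)n([C@H]2CO[C@@H](CO)C2)c2nc(N)nc(O)c21` differs from it in several places at once, and in this assay compound 2 gives 272 uM, a much higher number that lies well beyond the usual scatter; since the two compounds differ in more than one place, the gap cannot be pinned on any single change.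

Compound 3 `CCCCn1c(=O)n(C2OC(CO)[C@@H](O)[C@H]2O)c2nc(N)nc(O)c21` keeps the sugar-like ring of compound 1 and alters only the arm: propyl in place of 4-methoxyphenyl on a saturated chain carbon bound to an aromatic nitrogen. The aromatic ring with its single acceptor disappears and only a short saturated chain remains. Going by the values given here, no measured pair isolates this kind of change, so the expectation rests on compound 1 alone, whose value of 2 uM sets the starting point. A moderate move toward higher numbers is expected, a 3.0-fold higher number from compound 1 to compound 3 (0.48 log units; beyond the scatter), though it may well stay within the scatter. Compound 3 is estimated at 6 uM, within a range of 1.5 uM to 30 uM.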

Compound 3, concentration for half-maximal effect: 100 uM
The estimate for compound 3 lay 17-fold (1.22 log units) below the measured number; measured number outside the range, above it.
By their numbers in this assay, from the lowest: compound 1; then compound 3; then compound 2.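

This pair changes only the arm, with the sugar-like ring and the shared core left as they are, and in this assay going from 4-methoxybenzyl to butyl gives a 50-fold higher number from compound 1 to compound 3 (1.70 log units; beyond the scatter). The difference between compound 1 and compound 2 could not be tied to any one place, but this step shows that the group on a saturated chain carbon bound to an aromatic nitrogen can by itself shift the number by a large amount. The reason remains unknown, since the change removes the aromatic ring and its single hydrogen-bond acceptor together, and no supporting measurement explains the step.

The compounds shown leave open whether the aromatic ring or the methoxy group matters more, a question that plain benzyl on the same core could help to separate. They also leave open how the number would respond to a longer chain such as octyl, or to an arm ending in an amine or a carboxylic acid.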